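The source may report more compounds than this note shows. Statements on the series, on what has been measured and on what is new or still open speak of the compounds shown alone.

Among the compounds with values here, in a functional assay on L1210 cells (Mus musculus) for inhibition (a higher number here means a weaker inhibitor, a lower number a stronger inhibitor), compound 1 `Nc1nc(O)c2ncn(C/C=C\CO)c2n1` gives 680000 nM, the only exact number so far, and a value this high marks a very weak inhibitor. For compound 2 `Nc1ncnc2c1ncn2C1C=CCO1`, the reading is only a limit, > 500000 nM. Compound 3 `Nc1nc(O)c2ncn(C3C=CCO3)c2n1` has not yet been measured. It keeps the core of compound 1 and changes only the group on an aromatic nitrogen of the five-membered aromatic ring: a group of 5 heavy atoms (4 carbon, 1 oxygen; one five-membered non-aromatic ring with 1 hetero atom) in place of a group of 5 heavy atoms (4 carbon, 1 oxygen; no ring), on an aromatic nitrogen. In plain terms, a group with no ring, 4-hydroxybut-2-en-1-yl, gives way to a group of the same heavy-atom count that has a five-membered non-aromatic ring with 1 hetero atom. Within the data shown here, no measured pair shows this change on its own, so the size of the step has to be judged indirectly. Compound 2 carries the same ring group and stands at the limit of > 500000 nM, which offers no sign of a gain in strength. In this assay, no step beyond the usual scatter is expected, and the estimated step is a 1.1-fold lower number from compound 1 to compound 3 (0.05 log units; within the scatter). Compound 3 is expected at about 600000 nM, with an estimated range from 200000 nM to 1500000 nM.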

Compound 3, half-maximal inhibitory concentration: > 350000 nM
Compound 3: a limit, no number (the forecaster's own chance of this, stated with the estimate: 50%); the middle value does not contradict the limit.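

In this assay compound 3 gives only a limit, > 350000 nM. The step between compound 1 and compound 3 therefore cannot be read. The compounds shown leave open whether the ring group on the aromatic nitrogen gives stronger or weaker inhibition than 4-hydroxybut-2-en-1-yl, or about the same.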